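A few compounds are considered here, and "the series" means these few. Any claim that something is new, unique, unknown or untested is made for them only; others in the source may bear on it.

Working notes on the series. Among the compounds with values here, in an ADME assay on MRC5 cells (Homo sapiens) for inhibition, read by MTT assay, with a stated time of 72 h (on this read-out higher numbers stand for weaker inhibition and lower numbers for stronger inhibition), compound 2 `CCCCCCCCCCCCCCOC(=O)OCCc1ccc(O)c(O)c1` gives 9100 nM, the only actual number so far. Compound 1 `O=C(OCCCCCCO)OCCc1ccc(O)c(O)c1` reads > 50000 nM, which is a limit of the assay and not a number.

The next entry is compound 3 `CCCCCCCCCOC(=O)OCCc1ccc(O)c(O)c1`, whose difference from compound 2 is hydrogen in place of pentyl on a saturated chain carbon, nine bonds along the chain from an oxygen next to a carbonyl group. In words, this is hydrogen in place of pentyl on a saturated chain carbon, nine bonds along the chain from an oxygen next to a carbonyl group.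

Within the data shown here, one measured step bears on this change: an at least 5.4-fold lower number from compound 1 to compound 2 (0.73 log units; beyond the scatter), with octyl in place of hydroxy on a saturated chain carbon. There, a longer chain went with a lower number. Shortening the chain of compound 2 therefore points to a higher number in this assay. The guide is weak, as it is a single pair bounded on one side, and compound 3 carries no hydroxy group. The expected change is a 2.2-fold higher number from compound 2 to compound 3 (0.34 log units; beyond the scatter), a small rise close to the scatter. For compound 3 the estimated value is 20000 nM, with an expected range of 8000 nM to 50000 nM.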

Compound 3, half-maximal inhibitory concentration: 15900 nM
Compound 3: the middle estimate sits 1.3-fold (0.10 log units) above what was measured, and the stated range covers the measured number.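

In this assay, hydrogen in place of pentyl on a saturated chain carbon, nine bonds along the chain from an oxygen next to a carbonyl group, gives a 1.7-fold higher number from compound 2 to compound 3 (0.24 log units; within the scatter), so this change does not separate the two compounds, and the pentyl portion of the chain of compound 2 shows no measurable contribution at this read-out. The other new step, an at least 3.1-fold lower number from compound 1 to compound 3 (0.49 log units; beyond the scatter), shows that propyl in place of hydroxy, six bonds along the chain from an oxygen next to a carbonyl group, is already enough for a step beyond the scatter, whereas the earlier data held only the octyl replacement. Compound 1 reads > 50000 nM, which is a limit of the assay and not a number: the limit of > 50000 nM in this assay, at which 1 of the 3 values shown sits.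

The compounds shown leave open how the read-out responds to a chain shorter than that of compound 3 or to a longer chain than that of compound 2. They also leave open whether an amine or a carboxylic acid in place of the hydroxy of compound 1 would read like that hydroxy or like the unsubstituted chains.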